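Triazole to methylpyrazole on the para-substituted benzyl urea

This account rests on a few compounds, and the source may have more. Where it says the series, first, only, none or still open, it means among the compounds named here.

Among the measured compounds shown here, compound 1 `Cc1cc(C)c(NC(=O)N(Cc2ccc(-c3n[nH]c(C)n3)cc2)C2CCCCCC2)c(C)c1` is the only compound here with a number in an assay on microsomes from intestine for inhibition of acyl-CoA:cholesterol acyltransferase (Oryctolagus cuniculus) (a lower number here means a stronger inhibitor, a higher number a weaker inhibitor), where compound 1 gives 120 nM. Compound 2 `Cc1cc(C)c(NC(=O)N(Cc2cccc(-c3nn[nH]n3)c2)C2CCCCCC2)c(C)c1` gives in this assay only a limit, > 1000 nM, and no number. Compound 3 `Cc1cc(C)c(NC(=O)N(Cc2ccc(-c3cnn(C)c3)cc2)C2CCCCCC2)c(C)c1` differs from compound 1 by 1-methyl-1H-pyrazol-4-yl in place of 5-methyl-1H-1,2,4-triazol-3-yl on an aromatic carbon. For the measured compounds named here, no measured step exists between such a pair, so the expected size is uncertain; a modest loss of potency is expected, likely at or a little beyond the scatter. Compound 3 is therefore estimated at 250 nM (range 80 nM to 900 nM), a step of a 2.1-fold higher number from compound 1 to compound 3 (0.32 log units; beyond the scatter).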

Compound 3, half-maximal inhibitory concentration: 47 nM
Beside the measured number, compound 3's estimate is 5.3-fold (0.73 log units) above it, and the stated range ends above it.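

At this position, para to a large group, 1-methyl-1H-pyrazol-4-yl in place of 5-methyl-1H-1,2,4-triazol-3-yl gives in this assay a 2.6-fold lower number from compound 1 to compound 3 (0.41 log units; beyond the scatter), so the step is a gain rather than a loss. The entering ring has no hydrogen-bond donor, so a donor on this ring is not needed for potency in this pair. Nothing at hand accounts for the gain.

Whether the methyl on the pyrazole contributes remains open, since the pyrazole without it is not among the compounds shown. Also open, going by these compounds, is how an amine or a carboxylic acid would fare at this position.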